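Amine Size at the Acrylamide Tail: Predicting Compound 4

This account rests on a few compounds, and the source may have more. Where it says the series, first, only, none or still open, it means among the compounds named here.

Of the compounds shown here, three sharing one core have been tested in a functional assay on PC-3 cells (Homo sapiens) for antiproliferative activity, read by MTT assay, with a stated time of 72 h; on this read-out higher numbers stand for weaker inhibition and lower numbers for stronger inhibition. Compound 1 `COc1cc2ncnc(N3CCCc4ccccc43)c2cc1NC(=O)/C=C/CN(C)C` gives 1750 nM. Compound 2 `CCN(CC)C/C=C/C(=O)Nc1cc2c(N3CCCc4ccccc43)ncnc2cc1OC` differs from compound 1 by diethylamino in place of dimethylamino on a saturated chain carbon bound to a double-bonded chain carbon; compound 2 gives 6890 nM, a step of a 3.9-fold higher number from compound 1 to compound 2 (0.60 log units; beyond the scatter). Compound 3 `CN(C)C/C=C/C(=O)Nc1cc2c(N3CCCc4ccccc43)ncnc2cc1O[C@@H]1CCOC1` differs from compound 1 by oxolan-3-yl in place of methyl on an oxygen on an aromatic ring; compound 3 gives 4170 nM, a step of a 2.4-fold higher number from compound 1 to compound 3 (0.38 log units; beyond the scatter). Compound 4 `CCN(CC)C/C=C/C(=O)Nc1cc2c(N3CCCc4ccccc43)ncnc2cc1O[C@@H]1CCOC1` has not been measured in this assay; it differs from compound 3 by diethylamino in place of dimethylamino on a saturated chain carbon bound to a double-bonded chain carbon, the same change as the one made on the core of compound 1, now made on the core of compound 3. Within the data shown here, for compound 4 a step of about a 3.4-fold higher number from compound 3 to compound 4 (0.53 log units; beyond the scatter) is expected, resting on the single earlier instance of this change, a 3.9-fold higher number from compound 1 to compound 2 (0.60 log units; beyond the scatter), with no second example to test how well it carries over. Compound 4 is therefore estimated at 14000 nM, between 6500 nM and 32000 nM.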

Compound 4, half-maximal inhibitory concentration: 4270 nM
Beside the measured number, compound 4's estimate is 3.3-fold (0.52 log units) above it, outside the stated range (below it).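

On the core carrying oxolan-3-yl, the swap of dimethylamino for diethylamino gives a 1.0-fold higher number from compound 3 to compound 4 (0.01 log units; within the scatter), so in this assay the size of this step depends on the core it is made on: the same change on two cores in this assay, a 3.9-fold higher number (0.60 log units; beyond the scatter) from compound 1 to compound 2 and a 1.0-fold higher number (0.01 log units; within the scatter) from compound 3 to compound 4, 3.8-fold (0.58 log units) apart, beyond the scatter of two such steps

Read the other way, the swap of methyl for oxolan-3-yl on the oxygen gives a 1.6-fold lower number from compound 2 to compound 4 (0.21 log units; within the scatter), and this step also depends on the core: the same change on two cores in this assay, a 2.4-fold higher number (0.38 log units; beyond the scatter) from compound 1 to compound 3 and a 1.6-fold lower number (0.21 log units; within the scatter) from compound 2 to compound 4, 3.8-fold (0.58 log units) apart, beyond the scatter of two such steps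

The two changes therefore do not simply add up in this series, but these four compounds do not show why, and a single pair of cores gives no rule for any other core.

The compounds shown leave open how a ring amine such as morpholine, on the same saturated chain carbon, would read on each core.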